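The compounds below may be only part of what the source reports. "The series", "measured", "known", "first", "only" and "open" are said of these compounds alone.

Compound 1 `C#CCN(C)CCCOc1cc(NC(=O)CCCCCCCCC(=O)NO)ccc1Cl` is one of two compounds tested in an assay on isolated protein for inhibition of protein deacetylase HDAC6 (Homo sapiens), read by fluorescence; a higher number here means a weaker inhibitor, a lower number a stronger inhibitor. Compound 1 gives 160 nM, the higher of the two numbers; compound 2 `C#CCN(C)CCCOc1cc(NCc2ccc(C(=O)NO)cc2)ccc1Cl` gives 10 nM, a lower number, and the gap between them lies beyond the usual scatter. Compound 3 `C#CCN(C)CCCOc1cc(NC(=O)CCCCCCC(=O)NO)ccc1Cl` is built from compound 1 by one change: hydroxycarbamoyl in place of 2-(hydroxycarbamoyl)ethyl on a saturated chain carbon, six bonds along the chain from a carbonyl carbon. Two chain carbons are thereby removed. Among the measured compounds shown here, no measured pair shows this exact step, so the expected change from compound 1 to compound 3 is a 1.5-fold lower number from compound 1 to compound 3 (0.16 log units; within the scatter), a small shift within the scatter. Compound 3 is expected to give about 110 nM, estimated between 35 nM and 350 nM.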

Compound 3, half-maximal inhibitory concentration: 10 nM
For compound 3 the middle estimate is 11-fold (1.04 log units) above the measured one, outside the stated range (below it).
By their numbers in this assay, from the lowest: compounds 2 and 3 (each within the scatter of the next); then compound 1.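

In this assay, the step of a 16-fold lower number from compound 1 to compound 3 (1.20 log units; beyond the scatter) shows that potency is sensitive to chain length at this place: hydroxycarbamoyl in place of 2-(hydroxycarbamoyl)ethyl, which removes two chain carbons, is a large change rather than a small one. Nothing shown explains this difference.

Whether potency changes gradually or sharply with length remains open, as the intermediate case, with (hydroxycarbamoyl)methyl at this place, is not among the compounds shown. Also open, from the compounds shown here alone, is whether a carboxylic acid could stand in for the hydroxycarbamoyl end group.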